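Two limit values and a defluorinated analogue

The compounds below may be only part of what the source reports. "The series", "measured", "known", "first", "only" and "open" are said of these compounds alone.

Compound 1 `Cc1cnc(Nc2ccc([N+](=O)[O-])cc2)nc1Nc1nc2ccccc2s1`: > 50000 nM in a functional assay on PC-3 cells (Homo sapiens) for antiproliferative activity, read by MTT assay, with a stated time of 48 h (on this read-out higher numbers stand for weaker inhibition and lower numbers for stronger inhibition), a limit of the assay.
Compound 2 `Cc1cnc(Nc2ccc(S(C)(=O)=O)cc2)nc1Nc1nc2ccc(F)cc2s1`: > 50000 nM in this assay, likewise a limit.

Among the compounds with values here, compound 2 thus stands at a limit, not at a number, and the only other value shown is the same limit; the limit of > 50000 nM in this assay, at which 2 of the 2 values shown sit, leaves nothing to rank. Compound 3 `Cc1cnc(Nc2ccc(S(C)(=O)=O)cc2)nc1Nc1nc2ccccc2s1` differs from compound 2 by hydrogen in place of fluoro on an aromatic carbon. Within the data shown here, no measured step exists for this change. The step of a number no higher from compound 2 to compound 3 (the limit leaves the size open) is expected to be none beyond the scatter. For compound 3 the estimate in this assay is 50000 nM, expected range 15000 nM to 200000 nM, most likely again reported as a limit.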

Compound 3, half-maximal inhibitory concentration: > 50000 nM
Compound 3: a limit, no number; the forecaster's own chance of this, stated with the estimate: 85%; the middle value sits exactly at the limit.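

No new step can be read from compound 3 to compound 1 or compound 2, since all three stand at a limit: the limit of > 50000 nM in this assay, at which 3 of the 3 values shown sit.

The compounds shown leave open whether swapping fluoro for hydrogen or nitro for methylsulfonyl changes this assay at all.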